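Phenyl swap at the imine carbon: expected cytotoxicity of compound 4

This account rests on a few compounds, and the source may have more. Where it says the series, first, only, none or still open, it means among the compounds named here.

Measured in a functional assay on RAW264.7 cells (Mus musculus) for cytotoxicity, read by MTT assay, with a stated time of 48 h, tested at 100 uM; a lower number here means a weaker effect, a higher number a stronger effect of the compound at the concentration tested:
compound 1 `Cc1ccc(C2=Nn3c(Cc4ccc(S(C)(=O)=O)cc4)nnc3SC2)cc1` — 38.5%
compound 2 `CS(=O)(=O)c1ccc(Cc2nnc3n2N=C(c2cc(Cl)sc2S(N)(=O)=O)CS3)cc1` — 35.2%
compound 3 `CS(=O)(=O)c1ccc(Cc2nnc3n2N=C(c2ccc(-c4ccccc4)cc2)CS3)cc1` — 74.8%

Compound 2 gives the lowest of the three numbers in this assay; compound 1 sits nearest, with a gap that stays within the scatter, and compound 3 lies furthest, beyond the scatter. The next compound in the series is compound 4 `CS(=O)(=O)c1ccc(Cc2nnc3n2N=C(c2ccccc2)CS3)cc1`, not yet measured. Compared with compound 2 the change is phenyl in place of 5-chloro-2-sulfamoylthiophen-3-yl on a carbon with a double bond to nitrogen.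

For the measured compounds named here, two measured steps bear on this. The swap of one aryl group for another at the same position gave a number 3.3 percentage points lower from compound 1 to compound 2 (within the scatter), so an aryl exchange at this carbon need not move the read-out. Enlarging the aryl group gave a number 36.3 percentage points higher from compound 1 to compound 3 (beyond the scatter), a large rise, but compound 4 carries the smaller phenyl, not the extended one. Compound 4 is therefore expected to land near compounds 1 and 2, with a number 4.8 percentage points higher from compound 2 to compound 4 (within the scatter) as the expected step, most likely within the scatter. The estimate for compound 4 is 40%, in the range 25% to 60%.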

Compound 4, a percentage reported as activity, at one concentration (the size of the read-out at that concentration, not a potency): 55.5%
Compound 4: the middle estimate sits 15.5 percentage points below what was measured; the measured number falls inside the stated range.
By their numbers in this assay, from the lowest: compounds 2 and 1 (each within the scatter of the next); then compound 4; then compound 3.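

In this assay the exchange of aryl groups at the carbon with a double bond to nitrogen can move the read-out after all, since phenyl in place of 5-chloro-2-sulfamoylthiophen-3-yl gives a number 20.3 percentage points higher from compound 2 to compound 4 (beyond the scatter) at this position. The aromatic carbon on the phenyl ring works in both directions: hydrogen in place of methyl gives a number 17 percentage points higher from compound 1 to compound 4 (beyond the scatter) and hydrogen in place of phenyl gives a number 19.3 percentage points lower from compound 3 to compound 4 (beyond the scatter) in this series, so compound 4 falls between compound 1 and compound 3. No measured evidence accounts for these shifts.

On these data alone, what a methoxy or dimethylamino group on that aromatic carbon would give remains open, as does whether the chlorine or the sulfamoyl part of the thiophene group goes with the lower number. All these read-outs come from one concentration and give no potency.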